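This account rests on a few compounds, and the source may have more. Where it says the series, first, only, none or still open, it means among the compounds named here.

Measured in a functional assay on SEM cells (Homo sapiens) for cytotoxicity, read by MTT assay, with a stated time of 72 h; a higher number here means a weaker inhibitor, a lower number a stronger inhibitor:

- compound 1 `COC(=O)c1sc2cc(OC)ccc2c1Nc1cc(OC)c(OC)c(OC)c1`: 10.3 nM
- compound 2 `COC(=O)c1sc2cc(C)ccc2c1Nc1cc(OC)c(OC)c(OC)c1`: 0.7 nM
- compound 3 `COC(=O)c1sc2nc(C)ccc2c1Nc1cc(OC)c(OC)c(OC)c1`: 0.5 nM

Compound 3, at 0.5 nM, lies within the scatter of compound 2, at 0.7 nM. Compound 1 gives the clearly higher number, 10.3 nM. Compound 4 `COC(=O)c1sc2ncccc2c1Nc1cc(OC)c(OC)c(OC)c1` carries hydrogen in place of methyl on an aromatic carbon, next to the ring nitrogen: hydrogen in place of methyl on an aromatic carbon.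

Among the measured compounds shown here, one measured step bears on this change, a 15-fold lower number from compound 1 to compound 2 (1.17 log units; beyond the scatter), where methyl replaces methoxy on an aromatic carbon. It is large and beyond the scatter, so a single group swap in this series can move the number considerably. For the measured compounds named here, it does not show what happens when the group is lost altogether, and no measured compound lacks a group there. A moderate rise in the number is therefore expected, smaller than the measured step, though the direction is uncertain. The expected step is a 6.0-fold higher number from compound 3 to compound 4 (0.78 log units; beyond the scatter). For compound 4 the estimated value is 3 nM, with an expected range of 0.7 nM to 15 nM.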

Compound 4, half-maximal inhibitory concentration: 348 nM
Estimate against measurement, compound 4: 120-fold (2.06 log units) below; the whole stated range lies below it.
By their numbers in this assay, from the lowest: compounds 3 and 2 (each within the scatter of the next); then compound 1; then compound 4.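

In this assay, the number depends heavily on the methyl group on this aromatic carbon, next to the ring nitrogen: losing it gives a 700-fold higher number from compound 3 to compound 4 (2.84 log units; beyond the scatter). The earlier step, a 15-fold lower number from compound 1 to compound 2 (1.17 log units; beyond the scatter), exchanged one group for another at a site on a different core, whereas this one shows what happens when a group is removed and only hydrogen remains. Nothing available explains the size of this step.

Whether methyl itself is needed here remains open, since the compounds shown have only methyl or hydrogen at this carbon, and an ethyl group, a chlorine atom or an amine could fall near either compound 3 or compound 4. From the compounds shown here alone, it also remains open whether removing the methyl group from the core of compound 2 would give a step of similar size.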